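The source may hold more compounds than are shown below. What is called first, only, known or untested is meant among the compounds shown, and "the series" means these compounds.

Working notes on the series. Compound 3 `COc1ccc(Nc2nc(SCc3cn(CC(=O)NC(=O)Nc4ccccn4)nn3)nc(-c3ccc(C(C)C)cc3)c2C#N)cc1` gives the lowest number among the three measured compounds in a functional assay on ECa-109 cells (Homo sapiens) for inhibition, read by MTT assay, with a stated time of 72 h (a lower number here means a stronger inhibitor, a higher number a weaker inhibitor), at 5420 nM. Compound 1 `CC(C)c1ccc(-c2nc(SCc3cn(CC(=O)NC(=O)Nc4ccccn4)nn3)nc(Nc3ccccc3Cl)c2C#N)cc1` gives 23400 nM, and compound 2 `CC(C)c1ccc(-c2nc(SCc3cn(CC(=O)NC(=O)Nc4ccccn4)nn3)nc(Nc3cccc(C(F)(F)F)c3)c2C#N)cc1` gives 24200 nM; the step of a 1.0-fold higher number from compound 1 to compound 2 (0.01 log units; within the scatter) is within the scatter. The steps of a 4.3-fold lower number from compound 1 to compound 3 (0.64 log units; beyond the scatter) and a 4.5-fold lower number from compound 2 to compound 3 (0.65 log units; beyond the scatter) show a modest gain with the 4-methoxyphenyl. Compound 4 `COc1ccccc1Nc1nc(SCc2cn(CC(=O)NC(=O)Nc3ccccn3)nn2)nc(-c2ccc(C(C)C)cc2)c1C#N` carries the change (2-methoxyphenyl in place of 4-methoxyphenyl on a nitrogen on an aromatic ring). Among the measured compounds shown here, no measured step moves the methoxy group itself; the only bearing is that 2-chlorophenyl in compound 1 reads higher than 4-methoxyphenyl in compound 3. A step back toward compound 1 is therefore expected, as a 2.2-fold higher number from compound 3 to compound 4 (0.35 log units; beyond the scatter). Compound 4 is estimated at 12000 nM, in the range 4000 nM to 40000 nM.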

Compound 4, half-maximal inhibitory concentration: 8960 nM
Beside the measured number, compound 4's estimate is 1.3-fold (0.13 log units) above it, within the range that was stated.
By their numbers in this assay, from the lowest: compounds 3 and 4 (each within the scatter of the next); then compounds 1 and 2 (each within the scatter of the next).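

In this assay, 2-methoxyphenyl in place of 4-methoxyphenyl on the nitrogen is a 1.7-fold higher number from compound 3 to compound 4 (0.22 log units; within the scatter) and does not separate the two, so the methoxy group reads alike in both placings. The gain over the other aryl groups also survives in the 2-methoxyphenyl, with a 2.7-fold lower number from compound 2 to compound 4 (0.43 log units; beyond the scatter) and a 2.6-fold lower number from compound 1 to compound 4 (0.42 log units; beyond the scatter) as the steps that show it. Nothing available explains these steps.

Open, on these data alone, is whether a hydroxy or a dimethylamino group in place of the methoxy on the aromatic ring would read apart from compound 3 and compound 4 in this assay at all.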